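Tetrazolylacetamide series: difluorophenyl for pyridyl on the tetrazole

This account rests on a few compounds, and the source may have more. Where it says the series, first, only, none or still open, it means among the compounds named here.

Measured so far:
Compound 1, `Cc1cc(NC(=O)Cn2nnc(-c3ccccc3)n2)n(C2CCS(=O)(=O)CC2)n1`, an assay on HEK293 cells for activation of Kir3.1/Kir3.2 (Homo sapiens), read by thallium flux; a lower number here means that less compound is needed, a higher number that more compound is needed for the effect: > 10000 nM
Compound 2, `Cc1cc(NC(=O)Cn2nnc(-c3cccnc3)n2)n(C2CCCCC2)n1`, this assay: 1930 nM

Compound 1 reaches only the limit of this assay, as the limit of > 10000 nM in this assay, at which 1 of the 2 values shown sits, notes. Among the compounds with values here, compound 2 therefore gives the only number in this assay. Compound 3, `Cc1cc(NC(=O)Cn2nnc(-c3ccc(F)c(F)c3)n2)n(C2CCCCC2)n1`, differs from compound 2 by 3,4-difluorophenyl in place of pyridin-3-yl on an aromatic carbon. Within the data shown here, with no measured step of this kind to lean on, the expected step from compound 2 to compound 3 is a 1.6-fold lower number from compound 2 to compound 3 (0.21 log units; within the scatter), a change not clearly beyond the usual scatter. Compound 3 is thus estimated at 1200 nM in this assay, with a range from 300 nM to 5000 nM.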

Compound 3, half-maximal effective concentration: 116 nM
Estimate against measurement, compound 3: 10-fold (1.01 log units) above; the measured number lies below the stated range.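

In this assay, 3,4-difluorophenyl in place of pyridin-3-yl gives a 17-fold lower number from compound 2 to compound 3 (1.22 log units; beyond the scatter), so this position on the tetrazole responds strongly to the aromatic group it carries. Within the data shown here, this is the first comparison that changes one place only, and it favours the carbon-only ring bearing two fluorines over the ring containing nitrogen. Nothing measured here accounts for the step.

On these data alone, it remains open whether losing the ring nitrogen or gaining the fluorines carries the step. A chlorine or a methoxy group on the phenyl ring could help separate the two.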